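Sulfonamide series: tert-butyl to dimethylamino on the proline acyl

This account rests on a few compounds, and the source may have more. Where it says the series, first, only, none or still open, it means among the compounds named here.

Going by the values given here, compound 3 `CC(C)(C)CC(=O)N1CCC[C@H]1C(=O)N1CCC(NS(=O)(=O)c2cc(S(=O)(=O)c3ccccc3)ccc2C(F)(F)F)CC1` gives 120 nM in a functional assay on U2OS cells for antagonist activity at proto-oncogene Wnt-3 (Homo sapiens), read by a luciferase reporter, with a stated time of 18 h (on this read-out lower numbers stand for an effect already at smaller amounts and higher numbers for an effect only at larger amounts of compound), the lowest of the three numbers so far. Compound 2 `O=C(CN1CCCC1)N1CCC(NS(=O)(=O)c2cc(S(=O)(=O)c3ccccc3)ccc2C(F)(F)F)CC1` gives 190 nM in this assay, and the step of a 1.6-fold lower number from compound 2 to compound 3 (0.20 log units; within the scatter) is within the scatter. Compound 1 `CN(C)CC(=O)N1CCC(NS(=O)(=O)c2cc(S(=O)(=O)c3ccccc3)ccc2C(F)(F)F)CC1` gives 280 nM, and the step of a 2.3-fold lower number from compound 1 to compound 3 (0.37 log units; beyond the scatter) is modest but beyond the scatter. Between the two amine analogues the step of a 1.5-fold lower number from compound 1 to compound 2 (0.17 log units; within the scatter) is within the scatter.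

Compound 4 `CN(C)CC(=O)N1CCC[C@H]1C(=O)N1CCC(NS(=O)(=O)c2cc(S(=O)(=O)c3ccccc3)ccc2C(F)(F)F)CC1` differs from compound 3 by dimethylamino in place of tert-butyl on a saturated chain carbon bound to a carbonyl carbon. Among the compounds with values here, no measured step exchanges a tert-butyl for a dimethylamino; the closest information is that compounds 1 and 2 carry dimethylamino or pyrrolidin-1-yl on a saturated chain carbon bound to a carbonyl carbon and sit within the scatter of each other, while the steps of a 2.3-fold lower number from compound 1 to compound 3 (0.37 log units; beyond the scatter) and a 1.6-fold lower number from compound 2 to compound 3 (0.20 log units; within the scatter) show only a small gain from the whole neopentylcarbonyl-pyrrolidinyl fragment. The expectation is therefore a step in this assay of about a 1.3-fold higher number from compound 3 to compound 4 (0.12 log units; within the scatter), that is no change beyond the scatter, with a slight lean toward a higher number. Compound 4 is estimated at 160 nM in this assay, with a range of 70 nM to 360 nM.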

Compound 4, half-maximal effective concentration: 310 nM
For compound 4 the middle estimate is 1.9-fold (0.29 log units) below the measured one; the range from low to high includes it.
By their numbers in this assay, from the lowest: compounds 3, 2, 1 and 4 (each within the scatter of the next, the first and the last beyond it).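

In this assay, going by these compounds alone, the exchange of tert-butyl for dimethylamino on a saturated chain carbon bound to a carbonyl carbon gives a 2.6-fold higher number from compound 3 to compound 4 (0.41 log units; beyond the scatter), a modest step that isolates this one group, whereas the earlier steps to compound 3 replaced a whole fragment. With dimethylamino in this place, the larger fragment stays within the scatter of both smaller amine compounds, with a 1.1-fold higher number from compound 1 to compound 4 (0.04 log units; within the scatter) and a 1.6-fold higher number from compound 2 to compound 4 (0.21 log units; within the scatter), so the step of a 2.3-fold lower number from compound 1 to compound 3 (0.37 log units; beyond the scatter) is not retained once tert-butyl leaves. No supporting data offer an explanation for this difference.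

The compounds shown leave open whether pyrrolidin-1-yl, a carboxylic acid or a longer chain in this place on the 1-(neopentylcarbonyl)pyrrolidin-2-yl fragment would read closer to compound 3 or to compound 4. They also leave open whether neopentylcarbonyl placed directly on the shared core, in place of the (dimethylamino)methyl carbonyl unit of compound 1, would show a step of similar size, which would indicate whether the tert-butyl result depends on the pyrrolidin-2-yl unit.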